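The source may report more compounds than this note shows. Statements on the series, on what has been measured and on what is new or still open speak of the compounds shown alone.

Among the compounds with values here, in a functional assay on KB3 cells (Homo sapiens) for antiproliferative activity, read by MTT assay, with a stated time of 96 h (a higher number here means a weaker inhibitor, a lower number a stronger inhibitor), compound 1 `C=C(C)[C@H]1CC=C(C)[C@@]2(O)[C@@H]1[C@H](c1ccccc1Br)O[C@@H]2C(=O)OCC` gives 20000 nM, the highest of the two numbers known. Within the data shown here, compound 2 `C=C(C)[C@H]1CC=C(C)[C@@]2(O)[C@@H]1[C@H](c1ccccc1Br)O[C@@H]2C(=O)OC` gives 5000 nM in this assay, and the only measured step, a 4.0-fold lower number from compound 1 to compound 2 (0.60 log units; beyond the scatter), concerns the ester rather than the aromatic ring. Compound 3 `C=C(C)[C@H]1CC=C(C)[C@@]2(O)[C@@H]1[C@H](c1cccc(Br)c1)O[C@@H]2C(=O)OCC` differs from compound 1 as follows: 3-bromophenyl in place of 2-bromophenyl on a saturated ring carbon. Among the measured compounds shown here, no measured step touches the bromophenyl group, so nothing here points to a change beyond the scatter in this assay. Compound 3 is therefore expected to give 20000 nM, between 6000 nM and 70000 nM. That expectation means a step of no change at the digits printed from compound 1 to compound 3 (within the scatter).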

Compound 3, half-maximal inhibitory concentration: 3000 nM
Compound 3: middle estimate off by 6.7-fold (0.82 log units), on the high side; the measured number lies below the stated range.
By their numbers in this assay, from the lowest: compounds 3 and 2 (each within the scatter of the next); then compound 1.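

The aromatic ring matters as well as the ester: in this assay, 3-bromophenyl in place of 2-bromophenyl on the saturated ring carbon gives a 6.7-fold lower number from compound 1 to compound 3 (0.82 log units; beyond the scatter) with the same atoms, a step beyond the scatter. Within the data shown here, the earlier compounds showed only a change at the ester, so this is the first sign that the place of the bromine on the ring alone shifts the number. Nothing measured here accounts for the shift.

As far as these compounds go, whether plain phenyl, or chlorine or a methoxy group in place of the bromine, would behave likewise remains open. So does the outcome of joining the 3-bromophenyl group to the methyl ester of compound 2.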